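Triazole-linked series: cyclopropyl to 2-methylbenzyl on the chain

The compounds below may be only part of what the source reports. "The series", "measured", "known", "first", "only" and "open" are said of these compounds alone.

Three compounds of the shared core have numbers in a functional assay on RAW264.7 cells (Mus musculus) for inhibition, read by Griess assay, with stated times of 2 h and 24 h; a higher number here means a weaker inhibitor, a lower number a stronger inhibitor. Compound 1 `CCCCn1cc(COc2cc(O)c3c(c2)O[C@H](c2ccc(OC)c(O)c2)C/C3=N\O)nn1` gives 8900 nM. Compound 2 `CCCn1cc(COc2cc(O)c3c(c2)O[C@H](c2ccc(OC)c(O)c2)C/C3=N\O)nn1` gives 2340 nM. Compound 3 `COc1ccc([C@@H]2CC(=O)c3c(O)cc(OCc4cn(CC5CC5)nn4)cc3O2)cc1O` gives 11900 nM, the highest of the three numbers; its gap to compound 1 is within the scatter, while compound 2 is well lower.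

The step now followed goes from compound 3 to compound 4 `COc1ccc([C@@H]2CC(=O)c3c(O)cc(OCc4cn(Cc5ccccc5C)nn4)cc3O2)cc1O`: 2-methylphenyl in place of cyclopropyl on a saturated chain carbon bound to an aromatic nitrogen.

For the measured compounds named here, only one measured step alters the substituent on the saturated chain carbon bound to the aromatic nitrogen: a 3.8-fold lower number from compound 1 to compound 2 (0.58 log units; beyond the scatter), where removing a methyl three bonds along the chain gave the lower number. Going by the values given here, that step concerns a chain, not a ring, so it bears on the present change only loosely; no measured pair exchanges a small saturated ring for an aromatic one. The one hint available is that the smaller chain substituent was the stronger inhibitor, and compound 4 carries the larger group.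

Compound 4 is therefore expected to stay near compound 3 or to drift toward a somewhat higher number, with a 1.2-fold higher number from compound 3 to compound 4 (0.07 log units; within the scatter) expected to be within or barely beyond the scatter. The estimate for compound 4 in this assay is 14000 nM, with a range from 4500 nM to 40000 nM.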

Compound 4, half-maximal inhibitory concentration: 13100 nM
Beside the measured number, compound 4's estimate is 1.1-fold (0.03 log units) above it; the measured number falls inside the stated range.
By their numbers in this assay, from the lowest: compound 2; then compounds 1, 3 and 4 (each within the scatter of the next).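

In this assay, a 1.1-fold higher number from compound 3 to compound 4 (0.04 log units; within the scatter), so at this place on a saturated chain carbon bound to an aromatic nitrogen, exchanging cyclopropyl (3 heavy atoms) for 2-methylphenyl (7 heavy atoms) gives no reading that separates the two compounds. The earlier step, a 3.8-fold lower number from compound 1 to compound 2 (0.58 log units; beyond the scatter), showed a change beyond the scatter for a chain on the core of compound 1, whereas this pair shows that a saturated ring and an aromatic ring can be exchanged on the core of compound 3 without leaving the scatter. No measurement shown offers an explanation for either outcome.

The ring exchange is shown on the core of compound 3 only, so whether it would also stay within the scatter on the core of compound 1 remains open. Also open, as far as these compounds go, is whether an unsubstituted benzyl, an amine or a carboxylic acid in the same place would give a number that differs from those of compound 3 and compound 4 by more than the scatter.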